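The source may hold more compounds than are shown below. What is called first, only, known or untested is meant among the compounds shown, and "the series" means these compounds.

Compound 2 `Cc1c2c(n3c1CCN(C(=O)C1(N)CC1)C[C@@H](C)[C@H](C)Nc1cc-3ccc1C(N)=O)CC(C)(C)CC2=O` stands lowest of the two measured values in a physicochemical assay for solubility, at pH 7.4 (on this read-out higher numbers stand for higher solubility and lower numbers for lower solubility), where compound 2 gives 7 ug/mL. Its nearest neighbour is compound 1 `Cc1c2c(n3c1CCN(C(=O)CN)C[C@@H](C)[C@H](C)Nc1cc-3ccc1C(N)=O)CC(C)(C)CC2=O`, which in this assay gives 46 ug/mL. Among the measured compounds shown here, the single measured step, a 6.6-fold lower number from compound 1 to compound 2 (0.82 log units; beyond the scatter), shows that building up the group on the carbonyl carbon from aminomethyl to 1-aminocyclopropyl went together with a clearly lower number.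

Compound 3 `Cc1c2c(n3c1CCN(C(=O)[C@@H](O)C(C)C)C[C@@H](C)[C@H](C)Nc1cc-3ccc1C(N)=O)CC(C)(C)CC2=O` takes this carbonyl carbon one change further: 1-hydroxy-2-methylpropyl in place of 1-aminocyclopropyl on a carbonyl carbon. For the measured compounds named here, only the step of a 6.6-fold lower number from compound 1 to compound 2 (0.82 log units; beyond the scatter) bears on this change, and it speaks to the carbonyl substituent at the same place, not to exchanging nitrogen for oxygen, so the guidance is indirect. Because compound 2 already gives 7 ug/mL after a growth at that carbon, a further growth to 1-hydroxy-2-methylpropyl is expected to hold the number low, most likely with a step of a 1.4-fold lower number from compound 2 to compound 3 (0.15 log units; within the scatter) that stays within the scatter. The expected value for compound 3 in this assay is therefore 5 ug/mL, in a range from 1.5 ug/mL to 20 ug/mL.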

Compound 3, solubility: 30 ug/mL
Estimate against measurement, compound 3: 6.0-fold (0.78 log units) below; measured number outside the range, above it.
By their numbers in this assay, from the lowest: compound 2; then compounds 3 and 1 (each within the scatter of the next).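

In this assay, the fall seen at this carbonyl carbon does not hold for every larger group: with 1-hydroxy-2-methylpropyl in place of 1-aminocyclopropyl there is a 4.3-fold higher number from compound 2 to compound 3 (0.63 log units; beyond the scatter), so compound 3 goes against the simple pattern of a larger group giving a lower number. The comparison with the original group shows a 1.5-fold lower number from compound 1 to compound 3 (0.19 log units; within the scatter), which means that in these three compounds an amine on this group is not needed for a number in the range of compound 1. Nothing given here explains why these groups differ as they do.

The step from compound 2 to compound 3 changes several things at once, since the three-membered ring is lost, nitrogen gives way to oxygen and a defined stereocentre appears, so the compounds shown cannot say which of these changes matters. A 1-hydroxycyclopropyl group, which keeps the ring and carries a hydroxyl, or a 1-amino-2-methylpropyl group, which keeps the open chain and carries an amine, would help separate these changes.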